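A few compounds are considered here, and "the series" means these few. Any claim that something is new, unique, unknown or untested is made for them only; others in the source may bear on it.

Working notes on a functional assay on Caco-2 cells (Homo sapiens) for inhibition, read by MTT assay, with a stated time of 48 h, tested at 10 uM (on this read-out lower numbers stand for less inhibition of growth and higher numbers for more inhibition of growth at the one concentration tested), for a series built on a shared core. Compound 2 (`Cc1cc(=O)c2c(O)c(CN3CCCC3)c(O)c([C@H]3CCN(C)C[C@H]3O)c2o1`) stands at 22% within the scatter of compound 3 (`Cc1cc(=O)c2c(O)c(CN3CCN(C(=O)OC(C)(C)C)CC3)c(O)c([C@H]3CCN(C)C[C@H]3O)c2o1`) at 21% and of compound 1 (`Cc1cc(=O)c2c(O)c(CN3CCC(N4CCCCC4)CC3)c(O)c([C@H]3CCN(C)C[C@H]3O)c2o1`) at 31% so these three numbers set no order.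

Compound 4 (`Cc1cc(=O)c2c(O)c(CN3CC(O)CC3C(=O)O)c(O)c([C@H]3CCN(C)C[C@H]3O)c2o1`) has 2-carboxy-4-hydroxypyrrolidin-1-yl in place of pyrrolidin-1-yl on a saturated chain carbon bound to an aromatic carbon and has not yet been measured. Within the data shown here, no measured step isolates this change. Compound 1 at 31% and compound 3 at 21% carry different groups at that place and remain within the scatter of each other, so a large step is not expected here. The expected change is a slight fall (a number 7 percentage points lower from compound 2 to compound 4 (within the scatter)) that stays within the scatter. Compound 4 is estimated at 15% with an expected range (3% to 30%) still to be tested.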

Compound 4, percent growth inhibition at one concentration: 19%
Compound 4: the middle estimate sits 4 percentage points below what was measured; low and high end bracket the measured number.
By their numbers in this assay, from the lowest: compounds 4, 3, 2 and 1 (each within the scatter of the next, the first and the last beyond it).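

In this assay, 2-carboxy-4-hydroxypyrrolidin-1-yl in place of pyrrolidin-1-yl on a saturated chain carbon bound to an aromatic carbon gives a number 3 percentage points lower from compound 2 to compound 4 (within the scatter) as the first step read at this place, so the larger ring substituents leave the number of compound 2 within the scatter. Among these compounds, compound 4 at 19% and compound 1 at 31% are also the first pair to lie beyond the scatter of each other, which shows that the group at this place can separate the numbers in this assay even though the direct step does not. No measurement available here accounts for either result.

Still open, going by these compounds, is how the carboxylic acid and the hydroxyl each contribute, which a pyrrolidine bearing only one of them would separate. A methyl ester in place of the carboxylic acid, or a longer chain between the ring nitrogen and the core, would test this place further.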